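Notes on the step from compound 2 to compound 4

This account rests on a few compounds, and the source may have more. Where it says the series, first, only, none or still open, it means among the compounds named here.

In a functional assay on MCF7 cells (Homo sapiens) for inhibition, read by fluorescence, with a stated time of 72 h (on this read-out higher numbers stand for weaker inhibition of growth and lower numbers for stronger inhibition of growth), compound 2 `COc1ccc(Cn2cnc3c(Nc4cccc(Cl)c4)nc(N[C@H]4CC[C@H](N)CC4)nc32)cc1` gives 4800 nM. This lies within the scatter of both compound 1 `COc1ccc(Nc2nc(N[C@H]3CC[C@H](N)CC3)nc3c2ncn3CCC(C)C)c(OC)c1` at 6300 nM and compound 3 `COc1cc(Nc2nc(N[C@H]3CC[C@H](N)CC3)nc3c2ncn3CCC(C)C)cc(OC)c1` at 4500 nM, so the three values show no order.

Compound 4 `CCCCn1cnc2c(Nc3cccc(Cl)c3)nc(N[C@H]3CC[C@H](N)CC3)nc21` differs from compound 2 in one place: propyl in place of 4-methoxyphenyl on a saturated chain carbon bound to an aromatic nitrogen. In words, this is propyl in place of 4-methoxyphenyl on a saturated chain carbon bound to an aromatic nitrogen.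

Among the measured compounds shown here, the only measured step, a 1.4-fold lower number from compound 1 to compound 3 (0.15 log units; within the scatter), lies within the scatter and concerns a different place, on a nitrogen on an aromatic ring, so it bears only indirectly on this change. For the measured compounds named here, no measured step isolates the change itself. Compound 3, with a saturated chain without a ring on that aromatic nitrogen and a value of 4500 nM, stays within the scatter of compound 2, although it also differs elsewhere.

No step beyond the scatter is therefore expected in this assay. The expected change is a 1.2-fold lower number from compound 2 to compound 4 (0.08 log units; within the scatter). The estimate for compound 4 is 4000 nM, with an expected range of 1500 nM to 10000 nM.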

Compound 4, concentration for 50% growth inhibition: 2000 nM
Compound 4: middle estimate off by 2.0-fold (0.30 log units), on the high side; the range from low to high includes it.
By their numbers in this assay, from the lowest: compound 4; then compounds 3, 2 and 1 (each within the scatter of the next).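

In this assay, among the compounds shown here, propyl in place of 4-methoxyphenyl on a saturated chain carbon bound to an aromatic nitrogen gives a 2.4-fold lower number from compound 2 to compound 4 (0.38 log units; beyond the scatter), the first step that lies beyond the scatter, though it remains modest. For the compounds shown here, this position therefore responds to substitution, unlike the place of the only earlier step, a 1.4-fold lower number from compound 1 to compound 3 (0.15 log units; within the scatter), and the six-membered aromatic ring of 4-methoxyphenyl is not required for growth inhibition, since compound 4 carries no ring there and gives the lower number. Nothing available explains the difference between these two groups.

This single step does not separate loss of the ring from loss of the methoxy group. From the compounds shown here alone, how a plain benzyl, a longer chain such as hexyl, or a butyl chain ending in an amine would read at this position remains open.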